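From compound 2 to compound 3: a side-chain exchange

The source may hold more compounds than are shown below. What is called first, only, known or untested is meant among the compounds shown, and "the series" means these compounds.

In a functional assay on A549 cells (Homo sapiens) for antiproliferative activity, read by sulforhodamine B assay, with a stated time of 3 days (a higher number here means a weaker inhibitor of growth, a lower number a stronger inhibitor of growth), compound 1 (`COc1ccc(N2CCN(C)CC2)cc1Nc1ncc(F)c(Nc2ccc(F)cc2)n1`) gives 1130 nM and compound 2 (`CN1CCC(C(=O)Nc2cccc(Nc3ncc(F)c(Nc4ccc(F)cc4)n3)c2)CC1`) gives 1330 nM, so the two stand within the scatter of each other. Compound 3 (`O=C(NCCO)c1cccc(Nc2ncc(F)c(Nc3ccc(F)cc3)n2)c1`) carries (2-hydroxyethyl)carbamoyl in place of ((1-methylpiperidin-4-yl)carbonyl)amino on an aromatic carbon. Within the data shown here, no measured pair shows a change of this kind, so the expectation is tentative: a moderate move toward weaker growth inhibition in this assay. The estimated step is a 2.3-fold higher number from compound 2 to compound 3 (0.35 log units; beyond the scatter). Compound 3 is expected at 3000 nM, with an estimated range of 1000 nM to 10000 nM.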

Compound 3, concentration for 50% growth inhibition: 11900 nM
Compound 3: middle estimate off by 4.0-fold (0.60 log units), on the low side; the measured number lies above the stated range.
By their numbers in this assay, from the lowest: compounds 1 and 2 (each within the scatter of the next); then compound 3.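

On the aromatic carbon that carries this side chain, the group clearly matters in this assay: replacing ((1-methylpiperidin-4-yl)carbonyl)amino with (2-hydroxyethyl)carbamoyl gives an 8.9-fold higher number from compound 2 to compound 3 (0.95 log units; beyond the scatter). Among these compounds, this is the first step at this position, and it shows weaker growth inhibition when a group with a six-membered non-aromatic ring gives way to one with no ring. Nothing available explains the loss. The compounds shown leave open whether the ring, the hydroxyl or the way the amide is attached accounts for it. They also leave open whether a tertiary amine at the end of the same carbamoyl chain would behave differently.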